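Adding Bromo to Compound 2: What Is Expected

The compounds below may be only part of what the source reports. "The series", "measured", "known", "first", "only" and "open" are said of these compounds alone.

Among the compounds with values here, in an assay on isolated protein for antagonist activity at RAC-alpha serine/threonine-protein kinase (Homo sapiens), read by surface plasmon resonance, with a stated time of 30 min (on this read-out lower numbers stand for stronger inhibition and higher numbers for weaker inhibition), compound 2 `N=C(N/C(=N/O)c1nonc1N)c1ccccc1` gives 7190 nM, the higher of the two numbers measured so far. Compound 1 `N=C(N/C(=N/O)c1nonc1N)N1CCCN=C1N` gives 3230 nM in this assay, a gap beyond the usual scatter. Compound 3 `N=C(N/C(=N/O)c1nonc1N)c1ccccc1Br` differs from compound 2 by bromo in place of hydrogen on an aromatic carbon. Within the data shown here, no measured pair shows this change, so nothing in the data fixes its size or direction. The expected step is a 1.6-fold lower number from compound 2 to compound 3 (0.20 log units; within the scatter), most likely within the scatter. In this assay compound 3 is therefore expected to give about 4500 nM, with a range from 1500 nM to 13000 nM.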

Compound 3, half-maximal inhibitory concentration: 16400 nM
Beside the measured number, compound 3's estimate is 3.6-fold (0.56 log units) below it, outside the stated range (above it).
By their numbers in this assay, from the lowest: compound 1; then compound 2; then compound 3.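

Bromo in place of hydrogen on an aromatic carbon, ortho to a large group, gives in this assay the step of a 2.3-fold higher number from compound 2 to compound 3 (0.36 log units; beyond the scatter) and so moves the read-out towards weaker inhibition. Within the data shown here, this is the first sign that this place on the six-membered aromatic ring responds to substitution, and that this change does not favour inhibition there. No measured evidence bears on what lies behind the step.

The compounds shown leave open whether fluoro, an amine or a methoxy group at this same place would move the number the same way. They also leave open whether bromo on another carbon of that ring would do so.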